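The compounds below may be only part of what the source reports. "The series", "measured", "known", "first", "only" and "open" are said of these compounds alone.

Going by the values given here, compound 3 `COc1cc(-c2nn(-c3cccc(NC(=O)Nc4cccc(C(F)(F)F)c4)c3)cc2-c2ccncc2)ccc1Cl` gives 645 nM in a functional assay on U-251 cells (Homo sapiens) for inhibition, read by sulforhodamine B assay, with a stated time of 48 h (on this read-out lower numbers stand for stronger inhibition of growth and higher numbers for weaker inhibition of growth), the lowest of the three numbers measured so far; compound 2 `COc1cc(-c2nn(-c3cccc(NC(=O)Nc4ccc(Cl)c(Cl)c4)c3)cc2-c2ccncc2)ccc1Cl` gives 820 nM and compound 1 `COc1cc(-c2nn(-c3cccc(NC(=O)c4cccc(C(F)(F)F)c4)c3)cc2-c2ccncc2)ccc1Cl` gives 1620 nM. Compound 4 `COc1cc(-c2nn(-c3cccc(NC(=O)c4ccc(Cl)c(C(F)(F)F)c4)c3)cc2-c2ccncc2)ccc1Cl` carries 4-chloro-3-(trifluoromethyl)phenyl in place of (3-(trifluoromethyl)phenyl)amino on a carbonyl carbon. Among the compounds with values here, two measured steps bear on this change: a 2.5-fold lower number from compound 1 to compound 3 (0.40 log units; beyond the scatter) and a 2.0-fold lower number from compound 1 to compound 2 (0.30 log units; within the scatter), both replacing an aryl with an arylamino on the carbonyl carbon. Compound 4 reverses that exchange, so a rise in the number is expected, while a 1.3-fold lower number from compound 2 to compound 3 (0.10 log units; within the scatter) indicates the aryl substitution pattern itself made little difference. The step expected is therefore a 2.0-fold higher number from compound 3 to compound 4 (0.30 log units; within the scatter), a modest rise. Compound 4 is thus estimated at 1300 nM, with a range from 600 nM to 3000 nM.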

Compound 4, concentration for 50% growth inhibition: 3100 nM
Estimate against measurement, compound 4: 2.4-fold (0.38 log units) below, and the stated range ends below it.
By their numbers in this assay, from the lowest: compounds 3, 2, 1 and 4 (each within the scatter of the next, the first and the last beyond it).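

On the carbonyl carbon, 4-chloro-3-(trifluoromethyl)phenyl in place of (3-(trifluoromethyl)phenyl)amino gives a clear rise in this assay (a 4.8-fold higher number from compound 3 to compound 4 (0.68 log units; beyond the scatter)), and the step from the (3,4-dichlorophenyl)amino compound is also beyond the scatter (a 3.8-fold higher number from compound 2 to compound 4 (0.58 log units; beyond the scatter)). Chloro in place of hydrogen on an aromatic carbon stays within the scatter (a 1.9-fold higher number from compound 1 to compound 4 (0.28 log units; within the scatter)), so the added chloro does not separate these two amides. Nothing measured here accounts for these steps.

Open, as far as these compounds go, is how (4-chloro-3-(trifluoromethyl)phenyl)amino compares with compound 3, and whether a benzyl or a morpholine on the carbonyl carbon would stand nearer compound 3 or compound 4.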